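The source may report more compounds than this note shows. Statements on the series, on what has been measured and on what is new or still open speak of the compounds shown alone.

Measured in a functional assay on UACC-257 cells (Homo sapiens) for inhibition, read by sulforhodamine B assay, with a stated time of 48 h; a lower number here means that less compound is tolerated, a higher number that more compound is tolerated:
- compound 1 `COc1ccc(-c2cc(/C=C/C(=O)c3ccc(N)cc3)[nH]n2)cc1`: 9360 nM
- compound 2 `COc1cc(-c2cc(/C=C/C(=O)c3ccc(Cl)c(Cl)c3)[nH]n2)cc(OC)c1OC`: a limit of this assay only, > 100000 nM

Among the measured compounds shown here, compound 1 holds the only actual number in this assay; the other entry is a limit, not a figure, so no step between the two measured compounds can be sized. The one limit recorded is the limit of > 100000 nM in this assay, at which 1 of the 2 values shown sits, and it belongs to compound 2.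

Compound 3 `COc1ccc(-c2cc(/C=C/C(=O)c3ccc(N)cc3)[nH]n2)cc1OC` differs from compound 1 by methoxy in place of hydrogen on an aromatic carbon, placed on an aromatic carbon of a six-membered aromatic ring of carbon only, ortho to a methoxy group and meta to a large group. For the measured compounds named here, no measured pair shows the effect of this change, so the expectation is a step in this assay from compound 1 to compound 3 that stays within the usual scatter, with no clear direction; a modest loss of tolerance cannot be excluded. Compound 3 is estimated at 12000 nM, with a range from 4000 nM to 40000 nM, which corresponds to an expected step of a 1.3-fold higher number from compound 1 to compound 3 (0.11 log units; within the scatter).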

Compound 3, concentration lethal to 50% of the cells: 45700 nM
For compound 3 the middle estimate is 3.8-fold (0.58 log units) below the measured one; the measured number lies above the stated range.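

In this assay, among the compounds shown here, the only step that can be sized is a 4.9-fold higher number from compound 1 to compound 3 (0.69 log units; beyond the scatter). It shows that methoxy in place of hydrogen on this aromatic carbon, ortho to a methoxy group and meta to a large group, is not a neutral change here: the number moves towards more compound being tolerated. Compound 2 holds a limit, not a number, and differs from compound 3 in more than one place, so it sizes no step: the limit of > 100000 nM in this assay, at which 1 of the 3 values shown sits.

On these data alone, whether this step is specific to methoxy or would follow any group on this carbon remains open; a hydroxyl group, a fluorine or an amine there would test that. A single pair also leaves open whether the same change would give a similar step on a different version of the core.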